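Working notes: three measured compounds and one open estimate

A few compounds are considered here, and "the series" means these few. Any claim that something is new, unique, unknown or untested is made for them only; others in the source may bear on it.

Among the compounds with values here, all values so far come from a functional assay on 786-0 cells (Homo sapiens) for inhibition, read by sulforhodamine B assay, with a stated time of 48 h; on this read-out higher numbers stand for weaker inhibition of growth and lower numbers for stronger inhibition of growth.

Compound 1 `O=CN1CCN(c2ccc(Cl)cc2)C1=S`: 6800 nM
Compound 2 `N#C/C(=C\N1CCN(C(=O)c2ccco2)C1=S)C(N)=O`: 18000 nM
Compound 3 `COc1cc(C(=O)N2CCN(C=O)C2=S)cc(OC)c1OC`: 12700 nM

Compound 2 carries the highest of the three numbers. Its gap to compound 3 lies within the scatter, so nothing separates those two; compound 1 sits at a lower number, and that gap lies beyond the scatter.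

Compound 4 `N#C/C(=C\N1CCN(C(=O)c2ccco2)C1=S)C(=O)c1ccccc1` is the next entry and has not been measured. It differs from compound 2 in one place: phenyl in place of amino on a carbonyl carbon. Within the data shown here, no pair of measured compounds shares this change, so no step can be read off for it. With all three numbers clustered in a weak range, the expected step of a 1.8-fold lower number from compound 2 to compound 4 (0.26 log units; within the scatter) in this assay is small, with no direction that can be claimed beyond the scatter. Compound 4 is estimated at 10000 nM, within 3000 nM to 40000 nM.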

Compound 4, concentration for 50% growth inhibition: 16100 nM
Beside the measured number, compound 4's estimate is 1.6-fold (0.21 log units) below it; the measured number falls inside the stated range.
By their numbers in this assay, from the lowest: compounds 1, 3, 4 and 2 (each within the scatter of the next, the first and the last beyond it).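

In this assay, the first step read at this carbonyl carbon gives a 1.1-fold lower number from compound 2 to compound 4 (0.05 log units; within the scatter) for the change from carbamoyl to benzoyl. Swapping amino for phenyl, with its six-membered aromatic ring and without the hydrogen-bond donor, therefore resolves no difference in growth inhibition at this position. No measured evidence on the reason accompanies the series.

Still open, going by these compounds, is whether a methyl, an ethoxy or a substituted phenyl on this carbonyl carbon would separate from compound 2 beyond the scatter. A single step also cannot show whether the same change behaves alike on other members of the series.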